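Triazole thioether phthalimides: expectation for compound 4

The source may hold more compounds than are shown below. What is called first, only, known or untested is meant among the compounds shown, and "the series" means these compounds.

Measured compounds, with their values in a functional assay on MKN-45 cells (Homo sapiens) for cytotoxicity, read by MTT assay, with a stated time of 48 h; on this read-out lower numbers stand for stronger inhibition and higher numbers for weaker inhibition:

Compound 1 `C=CCSc1nnc(CC)n1N1C(=O)c2ccccc2C1=O` gives > 200000 nM.
Compound 2 `CCOC(=O)CSc1nnc(CC)n1N1C(=O)c2ccccc2C1=O` gives > 200000 nM.
Compound 3 `C=CCSc1nnc(CCC)n1N1C(=O)c2ccccc2C1=O` gives > 200000 nM.

Compound 3 stands only at a limit of this assay, not at a number. The value of compound 1 in this assay is likewise a limit. The value of compound 2 in this assay is a limit as well. All three sit at the limit of > 200000 nM in this assay, at which 3 of the 3 values shown sit, so neither step from compound 1 to compound 2 a step that the two limits leave unreadable from compound 1 to compound 2 nor from compound 1 to compound 3 a step that the two limits leave unreadable from compound 1 to compound 3 can be read in size or direction.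

Compound 4 `CCCc1nnc(SCC(=O)c2ccc(C)cc2)n1N1C(=O)c2ccccc2C1=O` differs from compound 3 by (4-methylphenyl)carbonyl in place of vinyl on a saturated chain carbon bound to a sulfur. Going by the values given here, no measured step bears on this change: the only two steps known are both unreadable between limits, and none of them touches the group that enters here. The series therefore gives no footing for the size or direction of this change, and the step is only estimated as an at least 3.3-fold lower number from compound 3 to compound 4 (0.52 log units; beyond the scatter), no more than a guess. Compound 4 is estimated at 60000 nM, within a range from 8000 nM to 200000 nM, with a substantial chance that this assay again reports only a limit.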

Compound 4, half-maximal inhibitory concentration: > 200000 nM
Compound 4: no number, only a limit; the forecaster's own chance of this, stated with the estimate: 45%; middle value at least 3.3-fold (0.52 log units) from the limit.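

In this assay compound 4 gives > 200000 nM, which is a limit and not a number. No new step can be read from compound 3 to compound 4, as both values are limits: the limit of > 200000 nM in this assay, at which 4 of the 4 values shown sit.

The compounds shown leave open whether any group on the saturated chain carbon bound to a sulfur, or any other change to the shared core, yields a number rather than a limit in this assay.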